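From methylamino to ((piperidin-4-yl)carbonyl)amino on compound 3

This account rests on a few compounds, and the source may have more. Where it says the series, first, only, none or still open, it means among the compounds named here.

Measured so far in an ADME assay on CHO cells (Cricetulus griseus) for cytotoxicity; on this read-out lower numbers stand for stronger inhibition and higher numbers for weaker inhibition:
- Compound 1 `CC(=O)N1CCC(C(=O)Nc2cc(Nc3cnccn3)nc(-c3ccnc(N4CCNCC4)c3)c2)CC1`: > 20000 nM
- Compound 2 `O=C(Cc1cccnc1)Nc1cc(Nc2cnccn2)nc(-c2ccnc(N3CCNCC3)c2)c1`: > 20000 nM
- Compound 3 `CNc1cc(Nc2cnccn2)nc(-c2ccnc(N3CCNCC3)c2)c1`: > 20000 nM

Each of these entries is a limit and not a number. Compound 3 therefore stands only at a limit, > 20000 nM, and has no exact place in this assay. The shared picture is the limit of > 20000 nM in this assay, at which 3 of the 3 values shown sit.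

Compound 4 `O=C(Nc1cc(Nc2cnccn2)nc(-c2ccnc(N3CCNCC3)c2)c1)C1CCNCC1` carries (piperidin-4-yl)carbonyl in place of methyl on a nitrogen on an aromatic ring.

Two measured steps change the group on that same nitrogen: a step that the two limits leave unreadable from compound 1 to compound 3 and a step that the two limits leave unreadable from compound 2 to compound 3. A third, a step that the two limits leave unreadable from compound 1 to compound 2, changes the group on the carbonyl carbon. None of them has a readable size, so they support no expected direction and no expected change beyond the scatter. Compound 4 is expected to remain near the same limit, and it may well be reported only as a limit.

The expected change is a number no higher from compound 3 to compound 4 (the limit leaves the size open).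

The estimate for compound 4 is 20000 nM, with an expected range from 9000 nM to 40000 nM.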

Compound 4, half-maximal inhibitory concentration: > 20000 nM
Compound 4 was reported as a limit; the forecaster's own chance of this, stated with the estimate: 75%; the middle value sits exactly at the limit.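

In this assay compound 4 gives > 20000 nM, which is a limit and not a number. No step from compound 1, compound 2 or compound 3 to compound 4 can be read, and one picture holds: the limit of > 20000 nM in this assay, at which 4 of the 4 values shown sit.

The compounds shown leave open where any of them would fall as an exact number, and whether changing the group on that nitrogen on an aromatic ring alters the read-out at all.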